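The source may report more compounds than this note shows. Statements on the series, on what has been measured and on what is new or still open speak of the compounds shown alone.

Of the compounds shown here, three have so far been measured in a functional assay on OVCAR-8 cells (Homo sapiens) for cytotoxicity, read by sulforhodamine B assay, with a stated time of 48 h, tested at 10 uM (a lower number here means a stronger effect, a higher number a weaker effect of the compound at the concentration tested), and a fourth is waiting for its result. Compound 1 `COc1cc(-c2cc(/C=C/C(=O)c3ccc(N)cc3)[nH]n2)cc(OC)c1OC` gives -1% in this assay, and compound 2 `COc1ccc(-c2cc(/C=C/C(=O)c3ccc(N)cc3)[nH]n2)cc1OC` gives 2%. These two differ in one place: hydrogen in place of methoxy on an aromatic carbon The step between them, a number 3 percentage points higher from compound 1 to compound 2 (within the scatter), is small. Compound 3 `COc1cc(C(=O)/C=C/c2cc(-c3cc(OC)c(OC)c(OC)c3)n[nH]2)cc(OC)c1OC` gives -76% in this assay, the strongest effect among the three, well apart from the other two. The difference between the core of compound 3 and the core of compound 1 is not broken down here.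

Compound 4 `COc1ccc(-c2cc(/C=C/C(=O)c3cc(OC)c(OC)c(OC)c3)[nH]n2)cc1OC` has not yet been measured. Going by the values given here, it differs from compound 3 in a single place: hydrogen in place of methoxy on an aromatic carbon This is the same change, at the same kind of position, as the one already seen between compound 1 and compound 2, now made on the core of compound 3. That earlier pair, however, sits at the weak end of the scale, where a change can pass unnoticed, so the flat step a number 3 percentage points higher from compound 1 to compound 2 (within the scatter) gives only limited guidance on what the same change does to a compound with a strong effect. The expected step is a number 21 percentage points higher from compound 3 to compound 4 (beyond the scatter), a modest weakening with wide uncertainty, resting on the small size of the step of a number 3 percentage points higher from compound 1 to compound 2 (within the scatter) and on the strong starting point of compound 3 at -76%. Compound 4 is therefore estimated to give about -55% in this assay, expected to fall between -85% and -10%.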

Compound 4, a percentage reported as activity, at one concentration (the size of the read-out at that concentration, not a potency): 6%
Beside the measured number, compound 4's estimate is 61 percentage points below it, outside the stated range (above it).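

Going by these compounds alone, putting hydrogen in place of methoxy on an aromatic carbon gives a number 82 percentage points higher from compound 3 to compound 4 (beyond the scatter) in this assay, so on this core the single methoxy group carries much of the strong effect seen for compound 3 at the concentration tested. The size of the step therefore did not carry over from one core to the other: the same change on two cores in this assay, a number 3 percentage points higher (within the scatter) from compound 1 to compound 2 and a number 82 percentage points higher (beyond the scatter) from compound 3 to compound 4, 79 percentage points apart, beyond the scatter of two such steps. This shows that, in these two pairs, a flat step on one core says little about the same change on another, but two pairs give no general rule, the read-out is a single-concentration effect rather than a potency, and nothing here says which feature of the two cores makes the difference, since they differ in more than one place.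

The compounds shown leave open whether the loss is specific to methoxy at this place, or whether another group there, such as a hydroxyl or an ethoxy group, would keep the effect of compound 3. They also leave open how much of that effect depends on the other methoxy groups of compound 3, each of which could be exchanged in the same way.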